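Bis(trifluoromethyl)benzenesulfonamide series: aryl swap on compound 1

The compounds below may be only part of what the source reports. "The series", "measured", "known", "first", "only" and "open" are said of these compounds alone.

Measured so far:
compound 1 `O=S(=O)(NCCNCc1cccc2ccccc12)c1cc(C(F)(F)F)cc(C(F)(F)F)c1` 19000 nM
compound 2 `CC(C)(C)c1ccc(CNCCCNS(=O)(=O)c2cc(C(F)(F)F)cc(C(F)(F)F)c2)cc1` 2500 nM

Among the compounds with values here, in a functional assay on BE(2)-C cells (Homo sapiens) for inhibition, read by MTT assay, with a stated time of 72 h (a higher number here means a weaker inhibitor of growth, a lower number a stronger inhibitor of growth), compound 1 gives 19000 nM, the higher of the two numbers so far; compound 2 gives 2500 nM, and the gap between the two lies beyond the usual scatter, so compound 1 is the weaker of the pair on this assay. Compound 2 is not a single-point neighbour of compound 1, so no step can be read between them.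

Compound 3 `CC(C)(C)c1ccc(CNCCNS(=O)(=O)c2cc(C(F)(F)F)cc(C(F)(F)F)c2)cc1` is the untested compound. It differs from compound 1 in one place: 4-(tert-butyl)phenyl in place of naphthalen-1-yl on a saturated chain carbon bound to an amine nitrogen. Within the data shown here, no pair with this change has been measured, so its size is only a guess. Compound 2 sits well below compound 1, and it carries the same entering group as compound 3, which is the only hint of direction. Compound 3 is therefore expected to come in below compound 1, with a step of a 3.2-fold lower number from compound 1 to compound 3 (0.50 log units; beyond the scatter) that is estimated to lie beyond the scatter but short of the full gap to compound 2. The estimate for compound 3 in this assay is 6000 nM, within a range of 2000 nM to 18000 nM.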

Compound 3, concentration for 50% growth inhibition: 14000 nM
Estimate against measurement, compound 3: 2.3-fold (0.37 log units) below, and the stated range covers the measured number.
By their numbers in this assay, from the lowest: compound 2; then compounds 3 and 1 (each within the scatter of the next).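

In this assay, 4-(tert-butyl)phenyl in place of naphthalen-1-yl on a saturated chain carbon bound to an amine nitrogen gives a 1.4-fold lower number from compound 1 to compound 3 (0.13 log units; within the scatter). At this place the two groups cannot be told apart, even though one aromatic ring stands in for two at an equal count of 10 heavy atoms. The 4-(tert-butyl)phenyl group alone does not go with the lowest number in the set: compound 3 carries it and gives 14000 nM, while compound 2 carries it too and gives 2500 nM. No measurement on hand accounts for the flat result at this place.

Still open, going by these compounds, is whether any aryl group at this place moves the number beyond the scatter: plain phenyl, naphthalen-2-yl or 4-methoxyphenyl would test how far the tolerance seen here extends. Also open, on these data alone, is how naphthalen-1-yl behaves on a longer chain, since only the 4-(tert-butyl)phenyl compounds 2 and 3 show a chain difference, and a single pair cannot say whether that difference holds for other aryl groups.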